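Swapping an indolyl for a pyrrolyl on a thioenone scaffold

The source may hold more compounds than are shown below. What is called first, only, known or untested is meant among the compounds shown, and "the series" means these compounds.

The series shares a thioenone core, seen in compound 1 `Cc1ccc(S/C(=C/c2c[nH]c3ccccc23)C(=O)c2ccc(Br)cc2)cc1`, compound 2 `CN(C)c1ccc(/C=C(/SCc2ccc(Cl)cc2)C(=O)c2ccc(Br)cc2)cc1` and compound 3 `Cc1ccc(S/C(=C/c2c[nH]c3ccccc23)C(=O)c2ccc(Cl)cc2)cc1`. In a functional assay on DU-145 cells (Homo sapiens) for inhibition, read by trypan blue exclusion, with a stated time of 96 h (on this read-out lower numbers stand for stronger inhibition of growth and higher numbers for weaker inhibition of growth), compound 1 gives 10000 nM, compound 2 gives 10000 nM and compound 3 gives 10000 nM, so compound 3 stands level with both of the others at the digits shown, within the scatter of the method. Among the compounds with values here, the only single-point step that has been measured, no change at the digits printed from compound 1 to compound 3 (within the scatter), shows that exchanging the halogen on the aromatic ring leaves the read-out where it was.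

Compound 4 `Cc1ccc(S/C(=C/c2ccc[nH]2)C(=O)c2ccc(Cl)cc2)cc1` differs from compound 3 by 1H-pyrrol-2-yl in place of 1H-indol-3-yl on a double-bonded chain carbon bound to a double-bonded chain carbon. Within the data shown here, no measured step in this set touches that position, so the expectation rests only on the flat picture among compounds 1, 2 and 3. Given that flatness, compound 4 is expected to change by no change at the digits printed from compound 3 to compound 4 (within the scatter), that is, no movement beyond the scatter. Compound 4 is therefore estimated at 10000 nM, with a range from 5000 nM to 20000 nM.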

Compound 4, concentration for 50% growth inhibition: 10000 nM
The estimate for compound 4 equals the measured number at the digits printed; the measured number falls inside the stated range.
By their numbers in this assay, from the lowest: compounds 1, 2, 3 and 4 (each within the scatter of the next).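

Putting 1H-pyrrol-2-yl in place of 1H-indol-3-yl on a double-bonded chain carbon bound to a double-bonded chain carbon gives no change at the digits printed from compound 3 to compound 4 (within the scatter) in this assay. Within the data shown here, this is the first measured step at this position, and it shows that losing the six-membered aromatic ring of carbon only from the group leaves the read-out where it was, with the five-membered aromatic ring and the single hydrogen-bond donor kept. No measured evidence on any property of these groups is available to account for this result.

The compounds shown leave open whether an amine, a carboxylic acid or a longer chain at this position would move the read-out. Since all four compounds stand level, they also leave open which structural change, if any, would separate one compound from another in this series.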